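The source may report more compounds than this note shows. Statements on the series, on what has been measured and on what is new or still open speak of the compounds shown alone.

Going by the values given here, compound 2 `COc1cc(-c2nnc3n2NC(c2ccco2)C(C(=O)c2cccc4ccccc24)S3)cc(OC)c1OC` holds the only true number in a functional assay on HepG2 cells (Homo sapiens) for cytotoxicity, read by MTT assay, with a stated time of 48 h (on this read-out lower numbers stand for stronger inhibition and higher numbers for weaker inhibition), where compound 2 gives 33900 nM. Compound 1 `COc1cc(-c2nnc3n2NC(c2ccco2)C(C(=O)c2ccc(O)cc2)S3)cc(OC)c1OC` reaches only a limit of this assay, > 100000 nM. Among the compounds with values here, the single measured step, an at least 2.9-fold lower number from compound 1 to compound 2 (0.46 log units; beyond the scatter), is the one that bears on the change at hand, and the limit of > 100000 nM in this assay, at which 1 of the 2 values shown sits, caps how much of it can be seen. Compound 3 `COc1cc(-c2nnc3n2NC(c2ccco2)C(C(=O)c2ccc([N+](=O)[O-])cc2)S3)cc(OC)c1OC` differs from compound 2 by 4-nitrophenyl in place of naphthalen-1-yl on a carbonyl carbon. Because an at least 2.9-fold lower number from compound 1 to compound 2 (0.46 log units; beyond the scatter) lowered the number on going to naphthalen-1-yl, moving back to a single six-membered aromatic ring of carbon only is expected to raise it, with the 4-nitrophenyl group itself untested. Compound 3 is therefore estimated at 70000 nM, within 25000 nM to 200000 nM. This amounts to an expected step of a 2.1-fold higher number from compound 2 to compound 3 (0.31 log units; beyond the scatter).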

Compound 3, half-maximal inhibitory concentration: 87800 nM
Beside the measured number, compound 3's estimate is 1.3-fold (0.10 log units) below it; the measured number falls inside the stated range.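

The change at this carbonyl carbon now has a single-ring group with a true number. In this assay, going to 4-nitrophenyl gives a 2.6-fold higher number from compound 2 to compound 3 (0.41 log units; beyond the scatter), so naphthalen-1-yl holds the lower number against both 4-hydroxyphenyl and 4-nitrophenyl. Nitro in place of hydroxy on an aromatic carbon gives an at least 1.1-fold lower number from compound 1 to compound 3 (0.05 log units; that floor lies within the scatter), so those two groups cannot be ordered, and the value of compound 1 stays a limit: the limit of > 100000 nM in this assay, at which 1 of the 3 values shown sits.

Still open, going by these compounds, is whether 4-aminophenyl or a saturated cyclohexyl group on the carbonyl carbon would give a lower or higher number.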